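Replacing 3-chlorophenyl with 4-methylphenyl on the carbonyl

The source may report more compounds than this note shows. Statements on the series, on what has been measured and on what is new or still open speak of the compounds shown alone.

Two members of the series have been measured. Compound 1 `Cc1ccc(C(=O)c2c(N)sc(Br)c2CC(C)(C)C)cc1` and compound 2 `COc1ccc(-c2sc(N)c(C(=O)c3cccc(Cl)c3)c2CC(C)(C)C)cc1` share the same core and the same assay. In an assay on CHO cells for displacement of a labelled ligand from adenosine receptor A1 (Homo sapiens), read by scintillation counting, tested at 10 uM (on this read-out higher numbers stand for more inhibition at the one concentration tested (going by the name of the read-out) and lower numbers for less inhibition), compound 1 gives 1%. In this assay compound 2 gives 1%, level with compound 1 at the digits shown and within the scatter of the method; no ordering between them is claimed. Compound 3 `COc1ccc(-c2sc(N)c(C(=O)c3ccc(C)cc3)c2CC(C)(C)C)cc1` awaits measurement. It differs from compound 2 in one place: 4-methylphenyl in place of 3-chlorophenyl on a carbonyl carbon. Compound 1 also carries a 4-methylphenyl on its carbonyl carbon and shows 1%, so nothing in the data points away from the low level seen so far. The expected step of a number 1 percentage points higher from compound 2 to compound 3 (within the scatter) is none beyond the scatter. Compound 3 is therefore expected to give about 2% in this assay, with a range from 0% to 12%.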

Compound 3, a percentage reported as inhibition, at one concentration (the size of the read-out at that concentration, not a potency): 1%
Estimate against measurement, compound 3: 1 percentage points above, within the range that was stated.
By their numbers in this assay, from the lowest: compounds 1, 2 and 3 (each within the scatter of the next).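

For the compounds shown here, with 4-methylphenyl in place of 3-chlorophenyl on a carbonyl carbon, this assay shows no change at the digits printed from compound 2 to compound 3 (within the scatter), the first direct one-place reading at this position, and neither aryl group lifts the read-out from its low level. With 4-methoxyphenyl in place of bromo on an aromatic carbon, this assay shows no change at the digits printed from compound 1 to compound 3 (within the scatter), so a second position in the series also gives no separation. No measurement on hand accounts for this flat result.

With all three compounds at this low level, the data cannot rank the groups at either position. As far as these compounds go, whether an amine or a carboxylic acid in place of 4-methylphenyl on the carbonyl carbon would raise the inhibition at the one concentration tested remains open.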